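The source may hold more compounds than are shown below. What is called first, only, known or untested is meant among the compounds shown, and "the series" means these compounds.

Measured compounds: compound 1 `Cc1cccc(NNS(=O)(=O)c2ccc(C(=O)NCC(=O)O)cc2)c1`, 80 nM; compound 2 `Cc1cccc(NNS(=O)(=O)c2ccc(S(C)(=O)=O)cc2)c1`, 43 nM; compound 3 `CC(=O)Nc1ccc(S(=O)(=O)NNc2ccccc2)cc1`, 71 nM in an assay for inhibition of Indoleamine 2,3-dioxygenase 1 (Homo sapiens), read by spectrophotometry, with stated times of 1 h and 4 h; on this read-out higher numbers stand for weaker inhibition and lower numbers for stronger inhibition.

Compound 3 stands second highest of the three numbers; its nearest neighbour is compound 1, its furthest compound 2, and both gaps lie within the scatter, so no order among the three can be read. Among the measured compounds shown here, the only measured step, a 1.9-fold lower number from compound 1 to compound 2 (0.27 log units; within the scatter), changes the substituent on the sulfonyl-bearing ring and is also within the scatter.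

Compound 4 `COc1ccc(NNS(=O)(=O)c2ccc(NC(C)=O)cc2)cc1` differs from compound 3 by methoxy in place of hydrogen on an aromatic carbon, on an aromatic carbon of a six-membered aromatic ring of carbon only, para to a large group. For the measured compounds named here, no measured step touches this ring; compounds 2 and 3 carry different groups there but also differ on the other ring, so their two values alone show nothing about the change. The step from compound 1 to compound 2 does not bear on it. In the absence of a precedent the step of a 1.0-fold lower number from compound 3 to compound 4 (0.01 log units; within the scatter) is expected to stay within the scatter. For compound 4 the estimate is 70 nM, range 25 nM to 200 nM.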

Compound 4, half-maximal inhibitory concentration: 254 nM
Compound 4: the middle estimate sits 3.6-fold (0.56 log units) below what was measured; the whole stated range lies below it.
By their numbers in this assay, from the lowest: compounds 2, 3 and 1 (each within the scatter of the next); then compound 4.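

In this assay, a 3.6-fold higher number from compound 3 to compound 4 (0.55 log units; beyond the scatter), so the aromatic carbon para to a large group is not indifferent to substitution: methoxy in place of hydrogen there weakens inhibition. Among the compounds shown here, this is the first step beyond the scatter, whereas the only earlier step, a 1.9-fold lower number from compound 1 to compound 2 (0.27 log units; within the scatter), showed no readable effect of a change elsewhere in the molecule. Nothing available accounts for the loss at this position.

With only hydrogen and methoxy shown at this carbon, it remains open whether any added group weakens inhibition here or whether the result is particular to methoxy; a fluorine, a hydroxyl or an ethoxy at the same place would help separate these cases. Also open, on these data alone, is whether the step carries over to compounds with methylsulfonyl on the other ring.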